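The compounds below may be only part of what the source reports. "The series", "measured", "known", "first", "only" and "open" are said of these compounds alone.

Compound 1 `O=C(NO)c1cccc(-c2cn([C@H]3C[C@@H](CO)N(CCCc4ccccc4)C3)nn2)c1` in an assay on Sf9 cells for inhibition of histone deacetylase 11 (Homo sapiens), read by fluorescence, tested at 0.5 uM (a higher number here means more inhibition at the concentration tested (going by the name of the read-out), a lower number less inhibition), gives < 10%, which is a limit of the assay and not a number.
Compound 2 `O=C(NO)c1cccc(-c2cn([C@@H]3C[C@@H](C(=O)O)N(CCCc4ccccc4)C3)nn2)c1` gives < 10%, again a limit.
Compound 3 `O=C(NO)c1cccc(-c2cn([C@@H]3C[C@@H](CO)N(CCCc4ccccc4)C3)nn2)c1` gives < 10%, again a limit.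

Compound 3 therefore stands at the limit of this assay, and so do the other two measured compounds, since (the limit of < 10% in this assay, at which 3 of the 3 values shown sit). The two measured steps leading to compound 3 cannot be read: a step that the two limits leave unreadable from compound 1 to compound 3, although (the fact that compounds 1 and 3 differ only in the configuration as drawn), and a step that the two limits leave unreadable from compound 2 to compound 3. Compound 4 `O=C(NO)c1ccc(-c2cn([C@@H]3C[C@@H](CO)N(CCCc4ccccc4)C3)nn2)cc1` differs from compound 3 in one place: 4-(hydroxycarbamoyl)phenyl in place of 3-(hydroxycarbamoyl)phenyl on an aromatic carbon. Going by the values given here, no measured step bears on this change, so no size can be taken from the data, and compound 3 itself shows only a limit. Compound 4 is expected to give about 5%, within 0% to 15%. The expected step that the limit leaves unreadable from compound 3 to compound 4 is thus estimated to be none beyond the scatter.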

Compound 4, a percentage reported as inhibition, at one concentration (the size of the read-out at that concentration, not a potency): 14%
Compound 4: the middle estimate sits 9 percentage points below what was measured; the measured number falls inside the stated range.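

Compound 4 is the only compound shown with a real number in this assay, so swapping 3-(hydroxycarbamoyl)phenyl for 4-(hydroxycarbamoyl)phenyl gives the first step here with a readable size, a number at least 4 percentage points higher from compound 3 to compound 4 (that floor lies within the scatter). This floor does not establish a real effect of the change. The earlier steps cannot be read, and most of the series still sits at a limit: the limit of < 10% in this assay, at which 3 of the 4 values shown sit.

Still open, going by these compounds, is whether 4-(hydroxycarbamoyl)phenyl would produce a change clearly beyond the scatter with an amine or a methyl ester in place of the hydroxymethyl.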